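The compounds below may be only part of what the source reports. "The series", "measured", "known", "first", "only" and "open" are said of these compounds alone.

Working notes on the series. In a functional assay on HeLa cells (Homo sapiens) for antiproliferative activity, read by MTT assay, with a stated time of 72 h (a lower number here means a stronger inhibitor, a higher number a weaker inhibitor), compound 1 (`CCN(CC)C(=S)SCC1=CCOC1=O`) gives 1390 nM, the lower of the two numbers in hand. Compound 2 (`O=C1CC2(CO1)CSC(=S)N2c1ccccc1`) gives 18000 nM, a gap to compound 1 that lies beyond the scatter. Compound 2 does not share the core of compound 1, so compound 1 serves as the reference here.

The step followed leads to compound 3 (`CNC(=S)SCC1=CCOC1=O`), which keeps the core of compound 1 and carries methylamino in place of diethylamino on a thiocarbonyl carbon. Among the measured compounds shown here, no pair of measured compounds differs in one place only, so the data do not size this change directly. Compound 1 holds the better of the two numbers at 1390 nM, and a move towards a weaker inhibitor in this assay is the working expectation, with a modest size and wide uncertainty. The expected step is a 2.5-fold higher number from compound 1 to compound 3 (0.40 log units; beyond the scatter), which may only just clear the scatter. For compound 3 the estimated value is 3500 nM, with an expected range of 1000 nM to 12000 nM.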

Compound 3, half-maximal inhibitory concentration: 36100 nM
Estimate against measurement, compound 3: 10-fold (1.01 log units) below, outside the stated range (above it).
By their numbers in this assay, from the lowest: compound 1; then compounds 2 and 3 (each within the scatter of the next).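

In this assay, methylamino in place of diethylamino on a thiocarbonyl carbon gives a 26-fold higher number from compound 1 to compound 3 (1.41 log units; beyond the scatter) and marks this position as far from indifferent to the group it carries. Compound 3 keeps the core of compound 1 unchanged, so the shared core alone does not secure the low number of compound 1, and the group on the thiocarbonyl carbon accounts for a large part of that reading. The step replaces a group with no hydrogen-bond donor by one with fewer heavy atoms and a hydrogen-bond donor, and nothing at hand assigns the change in activity to either difference.

From the compounds shown here alone, it remains open whether the step follows the hydrogen on the nitrogen or the shorter alkyl substitution, a question that dimethylamino, which keeps two alkyl groups on the nitrogen and has no such hydrogen, would bear on directly. Going by these compounds, it is also open whether a cyclic amine such as piperidine or a larger group such as dibenzylamino on the same thiocarbonyl carbon would match or improve on compound 1.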